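The compounds below may be only part of what the source reports. "The series", "measured", "known", "first", "only" and "open" are said of these compounds alone.

Compound 1 `COc1cc(C)cc(-c2c(-c3ccnc(-c4ccc(N(C)C)cc4)c3)cnn2CC#N)c1`: 50.1 nM
Compound 2 `COc1cc(C)cc(-c2nn(CC#N)cc2-c2ccnc(-c3ccc(N(C)C)cc3)c2)c1`: 353 nM

Both were tested in a functional assay on HCT-116 cells (Homo sapiens) for inhibition, read by sulforhodamine B assay, with a stated time of 48 h; on this read-out higher numbers stand for weaker inhibition of growth and lower numbers for stronger inhibition of growth. Compound 2 stands at the higher of the two numbers; compound 1 is lower by a margin beyond the usual scatter, so compound 1 inhibits growth more strongly. Compound 3 `Cc1cc(O)cc(-c2nn(CC#N)cc2-c2ccnc(-c3ccc(N(C)C)cc3)c2)c1` is compound 2 changed in one place: hydrogen in place of methyl on an oxygen on an aromatic ring. Among the compounds with values here, no measured pair shows this kind of change, so the expectation rests on compound 2 alone. The expected step in this assay is small, within the scatter: a 1.4-fold higher number from compound 2 to compound 3 (0.15 log units; within the scatter). Compound 3 is estimated at 500 nM, with a range from 150 nM to 1600 nM.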

Compound 3, concentration for 50% growth inhibition: 2710 nM
Estimate against measurement, compound 3: 5.4-fold (0.73 log units) below; measured number above the stated range.
By their numbers in this assay, from the lowest: compound 1; then compound 2; then compound 3.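

Going from methoxy to hydroxy on this aromatic ring is not a neutral swap: in this assay it gives a 7.7-fold higher number from compound 2 to compound 3 (0.89 log units; beyond the scatter). The removal of a single carbon from this oxygen is therefore enough to weaken growth inhibition clearly, which compounds 1 and 2 alone could not reveal.

Still open, going by these compounds, is how a longer chain such as ethoxy, or an amine in place of the oxygen, would compare with compound 2, and whether the same change would cost as much on compound 1. Nothing shown here explains the size of this step.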